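The source may hold more compounds than are shown below. What is called first, only, known or untested is meant among the compounds shown, and "the series" means these compounds.

Measured so far:
Compound 1 `O=C(/C=C/c1ccc(N2CCCCC2)cc1)c1ccsc1` in an ADME assay on Vero cells (Chlorocebus sabaeus) for cytotoxicity, with a stated time of 5 days (on this read-out higher numbers stand for weaker inhibition and lower numbers for stronger inhibition), gives 34400 nM.
Compound 2 `Cc1ccsc1C(=O)/C=C/c1ccc(N2CCCCC2)cc1` in this assay gives 63900 nM.
Compound 3 `Cc1csc(C(=O)/C=C/c2ccc(N3CCCCC3)cc2)c1` in this assay gives 56300 nM.

Compound 3 sits second highest of these three numbers; its nearest neighbour is compound 2, with a 1.1-fold lower number from compound 2 to compound 3 (0.05 log units; within the scatter), and its furthest is compound 1, with a 1.6-fold higher number from compound 1 to compound 3 (0.21 log units; within the scatter), so all three values overlap within the scatter. Compound 4 `O=C(/C=C/c1ccc(N2CCCCC2)cc1)c1ccc(I)s1` is not yet measured; it differs from compound 3 only by 5-iodothiophen-2-yl in place of 4-methylthiophen-2-yl on a carbonyl carbon. Among the compounds with values here, the steps that bear on this are the three swaps of the thiophene ring already seen: a 1.9-fold higher number from compound 1 to compound 2 (0.27 log units; within the scatter), a 1.6-fold higher number from compound 1 to compound 3 (0.21 log units; within the scatter) and a 1.1-fold lower number from compound 2 to compound 3 (0.05 log units; within the scatter), none beyond the scatter. Within the data shown here, no measured step introduces iodine. On that basis the step from compound 3 to compound 4 is expected to be small, a 1.1-fold lower number from compound 3 to compound 4 (0.05 log units; within the scatter). Compound 4 is therefore estimated at 50000 nM, within 20000 nM to 125000 nM.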

Compound 4, half-maximal inhibitory concentration: 56500 nM
Compound 4: the middle estimate sits 1.1-fold (0.05 log units) below what was measured, within the range that was stated.
By their numbers in this assay, from the lowest: compounds 1, 3, 4 and 2 (each within the scatter of the next).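

In this assay the swap to 5-iodothiophen-2-yl on a carbonyl carbon stays within the scatter against all three earlier compounds (a 1.0-fold higher number from compound 3 to compound 4 (0.00 log units; within the scatter), a 1.1-fold lower number from compound 2 to compound 4 (0.05 log units; within the scatter) and a 1.6-fold higher number from compound 1 to compound 4 (0.22 log units; within the scatter)). So this position, until now seen only with thiophen-3-yl and two methylthiophenes, also accepts iodine on the thiophene with no readable shift in this read-out. Nothing available explains this result. Going by these compounds, whether a carboxylic acid or an amine on the thiophene would also leave the number within the scatter remains open.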